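This account rests on a few compounds, and the source may have more. Where it says the series, first, only, none or still open, it means among the compounds named here.

In a functional assay on SK-BR-3 cells (Homo sapiens) for antiproliferative activity, read by MTT assay, with a stated time of 72 h (a higher number here means a weaker inhibitor, a lower number a stronger inhibitor), compound 1 `CCN1CCN(c2cc(C)c3cc(NC(=O)c4ccccc4F)ccc3n2)CC1` gives 38100 nM. Among the measured compounds shown here, compound 2 `CCN1CCN(c2cc(C)c3cc(NC(=O)c4ccccc4C)ccc3n2)CC1` gives 29200 nM, and the single measured step here, a 1.3-fold lower number from compound 1 to compound 2 (0.12 log units; within the scatter), is too small to count as a change. Compound 3 `Cc1cc(NCCN2CCN(C)CC2)nc2ccc(NC(=O)c3ccc(Cl)c(Cl)c3)cc12` gives 2690 nM, the lowest of the three numbers and beyond the scatter from both others. Compound 4 `Cc1cc(N2CCCC2)nc2ccc(NC(=O)c3ccc(Cl)c(Cl)c3)cc12` differs from compound 3 in one place: pyrrolidin-1-yl in place of (2-(4-methylpiperazin-1-yl)ethyl)amino on an aromatic carbon. For the measured compounds named here, no measured step touches this part of the shared core; the step between compound 1 and compound 2 alters a different part of the molecule and stays within the scatter, so it offers no guide. Without an anchor, the change in compound 4 is expected to give a moderately higher number, a 2.2-fold higher number from compound 3 to compound 4 (0.35 log units; beyond the scatter). Compound 4 is therefore estimated at 6000 nM, within a range from 1500 nM to 25000 nM.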

Compound 4, half-maximal inhibitory concentration: 43400 nM
For compound 4 the middle estimate is 7.2-fold (0.86 log units) below the measured one; measured number outside the range, above it.
By their numbers in this assay, from the lowest: compound 3; then compounds 2, 1 and 4 (each within the scatter of the next).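

Replacing (2-(4-methylpiperazin-1-yl)ethyl)amino with pyrrolidin-1-yl on the aromatic carbon next to the ring nitrogen gives a 16-fold higher number from compound 3 to compound 4 (1.21 log units; beyond the scatter) and so shows that the group at this position strongly affects the result. The change removes a six-membered ring with 2 hetero atoms, the connecting chain and a hydrogen-bond donor together, so this one step cannot separate them. Nothing available explains the loss of activity.

Which of these parts matters remains open. So does how a morpholine ring or a dimethylamino group on this carbon would compare.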